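Hydrogen for chloro on the aryl ring of compound 2

This account rests on a few compounds, and the source may have more. Where it says the series, first, only, none or still open, it means among the compounds named here.

Compound 1 `CCOC(=O)C1(O)CC(c2ccc(F)cc2)C2=C(CC(C)(C)CC2=O)O1`: "not active" (no number reported)
Compound 2 `CC1(C)CC(=O)C2=C(C1)NC(c1ccccc1)=CC2c1ccc(Cl)cc1`: 7.16%
Compound 3 `CCOC(=O)C1=CC(c2ccc(Cl)cc2)C2=C(CC(C)(C)CC2=O)N1`: 11.3%

In an assay on isolated protein for inhibition of glucose-6-phosphatase catalytic subunit 1 (Homo sapiens), read by inositol phosphate accumulation, with a stated time of 30 min, tested at 100 uM (on this read-out lower numbers stand for less inhibition and higher numbers for more inhibition at the one concentration tested (going by the name of the read-out)), compound 1 is reported only as "not active" (no number reported), with no number attached. Going by the values given here, compound 2 gives 7.16% and compound 3 gives 11.3%, and the one measured step, a number 4.1 percentage points higher from compound 2 to compound 3 (within the scatter), keeps the two within the usual scatter, so compound 2 stands alongside compound 3 rather than apart from it.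

Compound 4 `CC1(C)CC(=O)C2=C(C1)NC(c1ccccc1)=CC2c1ccccc1` differs from compound 2 in one place: hydrogen in place of chloro on an aromatic carbon. Among the compounds with values here, no measured step concerns this change; the only step available, a number 4.1 percentage points higher from compound 2 to compound 3 (within the scatter), alters a different place of the core and lies within the scatter. Nothing in the measured compounds therefore points to a shift beyond the scatter in this assay for this change.

Compound 4 is expected to give about 5%, within -6% to 17%. This estimate means a step of a number 2.2 percentage points lower from compound 2 to compound 4 (within the scatter), which is expected to stay within the scatter.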

Compound 4, a percentage reported as inhibition, at one concentration (the size of the read-out at that concentration, not a potency): "not active" (no number reported)
No number was reported for compound 4; there is nothing to compare the estimate with.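

Going by these compounds alone, compound 4 is reported as "not active" (no number reported) in this assay, so no step from compound 2 to compound 4 can be read. The compounds shown leave open whether hydrogen in place of chloro shifts inhibition beyond the usual scatter. Nothing further shown bears on this result.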